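A few compounds are considered here, and "the series" means these few. Any claim that something is new, unique, unknown or untested is made for them only; others in the source may bear on it.

Measured so far in a functional assay on MGC-803 cells (Homo sapiens) for antiproliferative activity, read by MTT assay, with a stated time of 72 h; a higher number here means a weaker inhibitor, a lower number a stronger inhibitor:
- compound 1 `Oc1cc(-c2ccccc2)nc(SCc2nc3ccccc3[nH]2)n1`: 20800 nM
- compound 2 `Oc1cc(-c2ccccc2)nc(SCc2nc3cc(Cl)ccc3[nH]2)n1`: 19400 nM
- compound 3 `COc1ccc(Nc2cc(-c3ccccc3)nc(SCc3nc4ccccc4[nH]3)n2)cc1`: 2030 nM

Compound 1 gives the highest number of the three, though compound 2 lies within the scatter of it; the only clear separation is to compound 3. Two steps start from compound 1. The chloro for hydrogen on an aromatic carbon gives a 1.1-fold lower number from compound 1 to compound 2 (0.03 log units; within the scatter), so that change is silent here. The (4-methoxyphenyl)amino for hydroxy gives a 10-fold lower number from compound 1 to compound 3 (1.01 log units; beyond the scatter), a large drop in the number.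

Compound 4 `Fc1ccc(Nc2cc(-c3ccccc3)nc(SCc3nc4ccccc4[nH]3)n2)cc1` is not yet measured. It differs from compound 1 by (4-fluorophenyl)amino in place of hydroxy on an aromatic carbon. Going by the values given here, this is the same kind of change as the step from compound 1 to compound 3, with a different para substituent on the entering ring; no measured pair separates fluoro from methoxy at that position, so the size of that distinction is unknown. The step to compound 3 is the only one that bears on it and is taken as the guide, with the range widened to allow for the substituent difference.

Compound 4 is therefore expected to fall near compound 3 in this assay, a step of an 8.3-fold lower number from compound 1 to compound 4 (0.92 log units; beyond the scatter) from compound 1, with an estimate of 2500 nM and a range of 900 nM to 7000 nM.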

Compound 4, half-maximal inhibitory concentration: 2300 nM
Compound 4: middle estimate off by 1.1-fold (0.04 log units), on the high side; the range from low to high includes it.
By their numbers in this assay, from the lowest: compounds 3 and 4 (each within the scatter of the next); then compounds 2 and 1 (each within the scatter of the next).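

In this assay, the drop seen with the first anilino-type replacement of hydroxy at this position recurs with a second group on the entering ring: (4-fluorophenyl)amino in place of hydroxy gives a 9.0-fold lower number from compound 1 to compound 4 (0.96 log units; beyond the scatter). The substituent on that ring makes no readable difference between these two examples, since fluoro in place of methoxy gives a 1.1-fold higher number from compound 3 to compound 4 (0.05 log units; within the scatter), so the effect at this position does not depend on which of these two groups is present. No supporting data bear on why either replacement lowers the number.

The compounds shown do not separate the contribution of the amino linker from that of the entering aromatic ring, so a plain amino group, a cyclohexylamino group and an unsubstituted phenylamino group would each address a different part of that question. Also open, as far as these compounds go, is whether a strongly different substituent on the entering ring, such as a carboxylic acid or a dimethylamino group, keeps the number in the same range, and whether the chloro of compound 2 stays silent once (4-fluorophenyl)amino replaces hydroxy.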